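The source may report more compounds than this note shows. Statements on the series, on what has been measured and on what is new or still open speak of the compounds shown alone.

In an in vivo ADME assay on the whole organism (strain 129/SvEvBrd x C57BL/6) for pharmacokinetics, with Mus musculus as the target, at a dose of 1 mg/kg by the intravenous route (a higher number here means faster removal of the compound, a lower number slower removal), compound 1 (`CC(=O)c1nc([C@@H](O)[C@H](O)[C@H](O)CO)c(C)[nH]1`) gives 7 mL/min/kg. Within the data shown here, compound 2 (`CC(O)c1nc([C@@H](O)[C@H](O)[C@H](O)CO)c[nH]1`) gives 16.4 mL/min/kg, the higher of the two numbers so far, and its gap to compound 1 lies beyond the usual scatter. Compound 3 (`CN(C)C(=O)c1nc([C@@H](O)[C@H](O)[C@H](O)CO)c[nH]1`) has not yet been measured in this assay. It differs from compound 2 at one place: dimethylcarbamoyl in place of 1-hydroxyethyl on an aromatic carbon. In words, dimethylcarbamoyl stands in place of 1-hydroxyethyl on an aromatic carbon. Among the measured compounds shown here, no measured pair isolates this change, so the only guide is the span of the two values in hand, with compound 2 at 16.4 mL/min/kg and compound 1 at 7 mL/min/kg. A small move toward slower removal is expected, not beyond the scatter, and the estimated step is a 1.4-fold lower number from compound 2 to compound 3 (0.14 log units; within the scatter). For compound 3 the estimate is 12 mL/min/kg, with an expected range of 5 mL/min/kg to 28 mL/min/kg.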

Compound 3, clearance: 11.3 mL/min/kg
The estimate for compound 3 lay 1.1-fold (0.03 log units) above the measured number; low and high end bracket the measured number.
By their numbers in this assay, from the lowest: compounds 1, 3 and 2 (each within the scatter of the next, the first and the last beyond it).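

In this assay, among these compounds, dimethylcarbamoyl in place of 1-hydroxyethyl on the aromatic carbon between two ring nitrogen atoms gives a 1.5-fold lower number from compound 2 to compound 3 (0.16 log units; within the scatter) and is the first single-place comparison. At this position, the swap brings in two more heavy atoms, a nitrogen and a carbonyl, and loses the hydrogen-bond donor, yet the two compounds cannot be told apart by clearance. No supporting data bear on why these two groups read alike.

As far as these compounds go, whether an amine or a carboxylic acid at this position would shift clearance beyond the scatter remains open. Also open, from the compounds shown here alone, are the separate contributions of the acetyl and ring methyl of compound 1, which differs from compound 2 in more than one place.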